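The source may hold more compounds than are shown below. What is called first, only, known or untested is meant among the compounds shown, and "the series" means these compounds.

Compound 2 `O=C(Nc1ccccc1)OC1C[C@@H]2CCCC[C@@H]2[C@H]1/C=C/c1ccc(-c2cccc(F)c2)cn1` holds the higher of the two numbers in an assay on cell membranes for displacement of a labelled ligand from proteinase-activated receptor 1 (Homo sapiens), read by scintillation counting, with a stated time of 60 min (on this read-out higher numbers stand for weaker inhibition and lower numbers for stronger inhibition), giving 360 nM. Its nearest neighbour is compound 1 `OC1C[C@@H]2CCCC[C@@H]2[C@H]1/C=C/c1ccc(-c2cccc(F)c2)cn1`, which gives 220 nM. Among the measured compounds shown here, the only measured step, a 1.6-fold higher number from compound 1 to compound 2 (0.21 log units; within the scatter), lies within the scatter. Compound 3 `CN(C)C(=S)OC1C[C@@H]2CCCC[C@@H]2[C@H]1/C=C/c1ccc(-c2cccc(F)c2)cn1` differs from compound 2 by a group of 5 heavy atoms (3 carbon, 1 nitrogen, 1 sulfur; no ring) in place of a group of 9 heavy atoms (7 carbon, 1 nitrogen, 1 oxygen; one six-membered aromatic ring of carbon only), on an oxygen on a saturated carbon. For the measured compounds named here, no measured step covers this exact change. Since swapping hydrogen for phenylcarbamoyl moved the number little, the expected step for compound 3 is small, a 1.2-fold lower number from compound 2 to compound 3 (0.08 log units; within the scatter), and within the scatter. Compound 3 is estimated at 300 nM, with a range from 120 nM to 750 nM.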

Compound 3, half-maximal inhibitory concentration: 120 nM
Estimate against measurement, compound 3: 2.5-fold (0.40 log units) above; the measured number falls inside the stated range.
By their numbers in this assay, from the lowest: compounds 3, 1 and 2 (each within the scatter of the next, the first and the last beyond it).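

In this assay, among the compounds shown here, the group on this oxygen can matter: a 3.0-fold lower number from compound 2 to compound 3 (0.48 log units; beyond the scatter), the first step here beyond the scatter, with a group of 5 heavy atoms and no ring replacing phenylcarbamoyl. Against the plain hydrogen, the same group gives a 1.8-fold lower number from compound 1 to compound 3 (0.26 log units; within the scatter), which stays within the scatter. No measured evidence bears on why these groups differ. The ring, the hydrogen-bond donor and the sulfur all change together in the first step, and the compounds shown do not separate them. On these data alone, how a dimethylcarbamoyl group, with oxygen in place of the sulfur, or a simple acetyl group would behave on this oxygen stays open.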